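Methoxy for fluoro on the fused ring of compound 1

The source may hold more compounds than are shown below. What is called first, only, known or untested is meant among the compounds shown, and "the series" means these compounds.

Three analogues of one core are in hand. In a functional assay on Caco-2 cells (Homo sapiens) for antiproliferative activity, read by MTT assay (on this read-out higher numbers stand for weaker inhibition and lower numbers for stronger inhibition), compound 1 `NS(=O)(=O)c1ccc(/N=C2\NC(=O)/C(=C3/C(=O)Nc4ccc(F)cc43)S2)cc1` gives 59900 nM, the second highest of the three numbers. Compound 2 `NS(=O)(=O)c1cccc(/N=C2\NC(=O)/C(=C3/C(=O)Nc4ccc(Cl)cc43)S2)c1` gives 5870 nM, a lower number and beyond the scatter. Compound 3 `Cc1cc(C)c2c(c1)/C(=C1/S/C(=N/c3ccc(S(N)(=O)=O)cc3)NC1=O)C(=O)N2` gives 146000 nM, a higher number, also beyond the scatter. Compound 4 `COc1ccc2c(c1)/C(=C1/S/C(=N/c3ccc(S(N)(=O)=O)cc3)NC1=O)C(=O)N2` is not yet measured in this assay. It differs from compound 1 by methoxy in place of fluoro on an aromatic carbon. For the measured compounds named here, no measured pair isolates this change, so the expected step is small: the estimated step of a 1.2-fold higher number from compound 1 to compound 4 (0.07 log units; within the scatter) is not expected to go beyond the scatter in either direction. Compound 4 is expected near 70000 nM, with a range of 20000 nM to 250000 nM.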

Compound 4, half-maximal inhibitory concentration: 98300 nM
For compound 4 the middle estimate is 1.4-fold (0.15 log units) below the measured one; the measured number falls inside the stated range.
By their numbers in this assay, from the lowest: compound 2; then compounds 1, 4 and 3 (each within the scatter of the next, the first and the last beyond it).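

Methoxy in place of fluoro on this aromatic carbon can now be read directly in this assay: a 1.6-fold higher number from compound 1 to compound 4 (0.22 log units; within the scatter). For the compounds shown here, this single change therefore does not carry the read-out beyond the scatter, a point that no earlier pair could show. No measured evidence bears on why the step has this size.

Going by these compounds, whether an amine or a carboxylic acid on this carbon would also stay within the scatter remains open. Compound 2 differs from compound 1 in more than one place, so its number cannot be assigned to either difference.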